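Thiazolyl hydrazones on A549 cells: swapping the thiazole aryl

A few compounds are considered here, and "the series" means these few. Any claim that something is new, unique, unknown or untested is made for them only; others in the source may bear on it.

Compound 1 `Fc1ccc(/C=N/Nc2nc(-c3cc(C(F)(F)F)cc(C(F)(F)F)c3)cs2)cc1F` gives 6230 nM in a functional assay on A549 cells (Homo sapiens) for inhibition, read by MTT assay, with a stated time of 48 h; on this read-out higher numbers stand for weaker inhibition and lower numbers for stronger inhibition.
Compound 2 `COc1cc(/C=N/Nc2nc(-c3ccc(C(F)(F)F)cc3)cs2)c(Br)c(Br)c1OC` gives 17600 nM in this assay.
Compound 3 `COc1cc(/C=N/Nc2nc(-c3cc(C(F)(F)F)cc(C(F)(F)F)c3)cs2)cc(Br)c1OC` gives 94200 nM in this assay.

Among these three numbers compound 2 stands second highest: compound 1 is its nearest neighbour and lies lower, compound 3 its furthest and lies higher. Among the measured compounds shown here, the one step measured between neighbours, a 15-fold higher number from compound 1 to compound 3 (1.18 log units; beyond the scatter), changes the aryl on the carbon with a double bond to nitrogen, not the aryl on the five-membered ring, so it does not bear directly on the change considered here.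

Compound 4 `COc1cc(/C=N/Nc2nc(-c3ccc(F)c(F)c3)cs2)c(Br)c(Br)c1OC` differs from compound 2 by 3,4-difluorophenyl in place of 4-(trifluoromethyl)phenyl on an aromatic carbon. For the measured compounds named here, no measured pair shows this particular exchange on the five-membered aromatic ring with 1 nitrogen and 1 sulfur, so the direction of any effect is unknown from these data. Compound 4 is therefore expected to stay within the scatter of compound 2, the step of a 1.0-fold higher number from compound 2 to compound 4 (0.01 log units; within the scatter) being the estimate. Compound 4 is estimated at 18000 nM, with a likely range from 6000 nM to 55000 nM.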

Compound 4, half-maximal inhibitory concentration: 8380 nM
Compound 4: middle estimate off by 2.1-fold (0.33 log units), on the high side; low and high end bracket the measured number.
By their numbers in this assay, from the lowest: compounds 1 and 4 (each within the scatter of the next); then compound 2; then compound 3.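

Among the compounds shown here, this is the first measured exchange on the aromatic carbon of the five-membered aromatic ring with 1 nitrogen and 1 sulfur: in this assay, 3,4-difluorophenyl in place of 4-(trifluoromethyl)phenyl gives a 2.1-fold lower number from compound 2 to compound 4 (0.32 log units; beyond the scatter). The position therefore responds to a change of aryl, with a modest step that lies beyond the scatter and runs towards stronger inhibition. This reading rests on a single pair, in which the aryl on the carbon with a double bond to nitrogen stays the same.

Nothing in the data given here explains the step. From the compounds shown here alone, it remains open whether the same exchange would give a similar step with the aryl of compound 1 or compound 3 on the carbon with a double bond to nitrogen, and how an amine or a carboxylic acid on the phenyl ring at this position would read out.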